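This account rests on a few compounds, and the source may have more. Where it says the series, first, only, none or still open, it means among the compounds named here.

Of the compounds shown here, three sharing one core have been measured in an ADME assay on HFF cells (Homo sapiens) for cytotoxicity, read by MTT assay, with a stated time of 72 h; on this read-out higher numbers stand for weaker inhibition and lower numbers for stronger inhibition. Compound 1 `O=C1O/C(=C\Cn2cc(-c3ccc(Br)cc3)nn2)C(OCc2ccccc2)=C1OCc1ccccc1` gives in this assay only a limit, > 100000 nM, which is the limit of > 100000 nM in this assay, at which 1 of the 3 values shown sits. Compound 2 `O=C1O[C@H]([C@@H](O)Cn2cc(-c3ccc(Br)cc3)nn2)C(OCc2ccccc2)=C1OCc1ccccc1` gives 5100 nM, the highest of the two numbers recorded, while compound 3 `CC(C)(C)OC(=O)N1CCN(C(=S)SCc2cn(C[C@H](O)[C@H]3OC(=O)C(OCc4ccccc4)=C3OCc3ccccc3)nn2)CC1` gives 60 nM, and the gap between these two lies beyond the scatter of repeated measurement. Compound 4 `Cc1ccc(S(=O)(=O)NCc2cn(C[C@H](O)[C@H]3OC(=O)C(OCc4ccccc4)=C3OCc3ccccc3)nn2)cc1` has not yet been measured. It differs from compound 2 in one place: (((4-methylphenyl)sulfonyl)amino)methyl in place of 4-bromophenyl on an aromatic carbon. The entering group stands on an aromatic carbon of a five-membered aromatic ring with 3 nitrogen, two ring bonds from the ring atom that bears a large group. Going by the values given here, no pair of measured compounds shares this exact change, so the only guide is the pair of numbers from compound 2 and compound 3, which shows that the shared core can give values far below that of compound 2. On that basis the number for compound 4 is expected to fall relative to compound 2, beyond the scatter but by less than the gap down to compound 3, the expected step being a 3.4-fold lower number from compound 2 to compound 4 (0.53 log units; beyond the scatter). Compound 4 is therefore estimated at 1500 nM, within a range from 300 nM to 8000 nM.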

Compound 4, half-maximal inhibitory concentration: 50 nM
Beside the measured number, compound 4's estimate is 30-fold (1.48 log units) above it; the measured number lies below the stated range.
By their numbers in this assay, from the lowest: compounds 4 and 3 (each within the scatter of the next); then compound 2. At a limit, above all of these: compound 1.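

In this assay, going by these compounds alone, the aromatic carbon of the five-membered aromatic ring with 3 nitrogen proves to be a place where one change moves the number a long way: (((4-methylphenyl)sulfonyl)amino)methyl in place of 4-bromophenyl gives a 100-fold lower number from compound 2 to compound 4 (2.01 log units; beyond the scatter), the first step on this read-out that can be traced to a single change. Compound 3 gives 60 nM and compound 4 gives 50 nM, two values within the scatter of each other, so two quite different groups on this aromatic carbon reach the same level on the shared core. Nothing measured here accounts for the size of the step.

The compounds shown leave open which part of the entering group goes with the step: a plain aminomethyl group or a carboxylic acid on the same aromatic carbon would separate the linking chain from the 4-methylphenyl ring. They also leave open whether the number of compound 2 is tied to the bromine or to the directly attached aromatic ring, which a plain phenyl or a longer alkyl chain at this carbon could distinguish.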